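The source may report more compounds than this note shows. Statements on the series, on what has been measured and on what is new or still open speak of the compounds shown alone.

Measured in a physicochemical assay for lipophilicity, at pH 7.4; a lower number here means a more polar compound, a higher number a more lipophilic compound:
- compound 1 `C[C@H]1C(=O)N(C)C=Cc2ccccc21`: 4.3
- compound 2 `COCCOc1ccc2c(c1)C=CN(C)C(=O)[C@@H]2C`: 4

Within the data shown here, compound 2, at 4, stands within the scatter of compound 1, the only other measured compound. Compound 3 `C[C@H]1C(=O)N(C)C=Cc2cc(CC3CCOCC3)ccc21` carries (oxan-4-yl)methyl in place of 2-methoxyethoxy on an aromatic carbon, with (oxan-4-yl)methyl in place of 2-methoxyethoxy on an aromatic carbon. Among the measured compounds shown here, no measured step covers this exchange directly. The nearest evidence is a number 0.30 log units lower from compound 1 to compound 2 (within the scatter), so no shift beyond the scatter is expected in this assay. The expected step is a number 0.20 log units higher from compound 2 to compound 3 (within the scatter). Compound 3 is estimated at 4.2, with an expected range of 3.8 to 4.6.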

Compound 3, distribution coefficient: 5.4
Compound 3: middle estimate off by 1.20 log units, on the low side, and the stated range ends below it.
By their numbers in this assay, from the lowest: compounds 2 and 1 (each within the scatter of the next); then compound 3.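

In this assay this position proves sensitive to the substituent: (oxan-4-yl)methyl in place of hydrogen gives a number 1.10 log units higher from compound 1 to compound 3 (beyond the scatter) while 2-methoxyethoxy stays within the scatter of hydrogen. Exchanging 2-methoxyethoxy for (oxan-4-yl)methyl gives a number 1.40 log units higher from compound 2 to compound 3 (beyond the scatter) and shows that two oxygen-containing groups with no net charge need not read alike here. Nothing available accounts for the size of these steps.

On these data alone, the exchange alters the ring, heavy-atom count and oxygen count together, and the contribution of each stays open. As far as these compounds go, how an amine or a carboxylic acid on this carbon would read also stays open.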